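The compounds below may be only part of what the source reports. "The series", "measured", "known", "first", "only" and "open" are said of these compounds alone.

Among the compounds with values here, compound 2 `O=C(CCN1CCN(c2ccnc3cc(Cl)ccc23)CC1)N/N=C/c1c[nH]c2ccccc12` gives 43.3% in a physicochemical assay for inhibition, read by spectrophotometry, with a stated time of 24 h, tested at 2.5 mM; on this read-out lower numbers stand for less inhibition and higher numbers for more inhibition at the one concentration tested (going by the name of the read-out); of the two numbers measured so far, that of compound 2 reads lowest, but compound 1 `COc1cc(/C=N/NC(=O)CCN2CCN(c3ccnc4cc(Cl)ccc34)CC2)ccc1O` gives 50.7%, and the step of a number 7.4 percentage points lower from compound 1 to compound 2 (within the scatter) lies within the scatter. Compound 3 `COc1cc(/C=N/NC(=O)CCN2CCN(c3ccnc4cc(Cl)ccc34)CC2)ccc1OC(C)C` differs from compound 2 by one change (4-isopropoxy-3-methoxyphenyl in place of 1H-indol-3-yl on a carbon with a double bond to nitrogen). Within the data shown here, the only measured step that bears on it is the exchange of the group on the carbon with the double bond to nitrogen, a number 7.4 percentage points lower from compound 1 to compound 2 (within the scatter), which did not rise above the scatter. Compound 3 carries once more a phenyl ring bearing a methoxy, as compound 1 does, so a number near that of compound 1 is anticipated. The estimated step is a number 4.7 percentage points higher from compound 2 to compound 3 (within the scatter), with no change beyond the scatter. Compound 3 is therefore expected to give 48%, within a range from 34% to 62%.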

Compound 3, a percentage reported as inhibition, at one concentration (the size of the read-out at that concentration, not a potency): 15.7%
Compound 3: the middle estimate sits 32.3 percentage points above what was measured; measured number below the stated range.
By their numbers in this assay, from the lowest: compound 3; then compounds 2 and 1 (each within the scatter of the next).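

In this assay, the group on the carbon with a double bond to nitrogen turns out to matter more than the first exchange suggested. Isopropyl in place of hydrogen on an oxygen on an aromatic ring, a change confined to one atom of that group, gives a number 35 percentage points lower from compound 1 to compound 3 (beyond the scatter) and is the first step here to pass beyond the scatter. The exchange of 1H-indol-3-yl for 4-isopropoxy-3-methoxyphenyl gives a number 27.6 percentage points lower from compound 2 to compound 3 (beyond the scatter) as well, so a phenyl ring bearing a methoxy does not by itself secure the number, and what sits on the other oxygen counts.

Nothing available explains this loss of inhibition. The compounds shown leave open whether it belongs to isopropyl alone or would also come with ethyl, a longer chain or a chain ending in an amine on that oxygen.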